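Notes on compound 4: one ethyl ester opened to acid

The source may hold more compounds than are shown below. What is called first, only, known or untested is meant among the compounds shown, and "the series" means these compounds.

Measured so far in an in vitro ADME assay on a cell-free system (plasma) for pharmacokinetics; on this read-out lower numbers stand for a shorter-lived compound and higher numbers for a longer-lived compound:
Compound 1 `CCOC(=O)CCCN(C(=O)/C(C)=C/c1ccc(C(=O)Oc2ccc(C(=N)N)cc2)cc1)C(C(=O)OCC)C(=O)OCC` gives < 0.0167 h, which is a limit of the assay and not a number.
Compound 2 `CCOC(=O)C(C(=O)OCC)N(CCCC(=O)O)C(=O)/C(C)=C/c1ccc(C(=O)Oc2ccc(C(=N)N)cc2)cc1` gives 0.483 h.
Compound 3 `C/C(=C\c1ccc(C(=O)Oc2ccc(C(=N)N)cc2)cc1)C(=O)N(CC(=O)O)C1CCCC1` gives 0.383 h.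

Compound 1 thus sits at the limit of < 0.0167 h in this assay, at which 1 of the 3 values shown sits, so only a bound is known for it. Compound 4 `CCOC(=O)CCCN(C(=O)/C(C)=C/c1ccc(C(=O)Oc2ccc(C(=N)N)cc2)cc1)C(C(=O)O)C(=O)OCC` differs from compound 1 by hydrogen in place of ethyl on an oxygen next to a carbonyl group. Within the data shown here, the one measured step of this kind, an at least 28-fold higher number from compound 1 to compound 2 (1.46 log units; beyond the scatter), concerns a different ethoxycarbonyl group of the shared core but is the only guide here. For compound 4 a rise of similar size in this assay is therefore expected. The expected step is an at least 17-fold higher number from compound 1 to compound 4 (1.25 log units; beyond the scatter). The estimate for compound 4 is 0.3 h, with a range from 0.05 h to 1.5 h.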

Compound 4, half-life: 0.233 h
Beside the measured number, compound 4's estimate is 1.3-fold (0.11 log units) above it; the range from low to high includes it.
By their numbers in this assay, from the lowest: compounds 4, 3 and 2 (each within the scatter of the next, the first and the last beyond it). At a limit, below all of these: compound 1.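

In this assay, bis(ethoxycarbonyl)methyl changed to carboxy(ethoxycarbonyl)methyl gives an at least 13-fold higher number from compound 1 to compound 4 (1.14 log units; beyond the scatter). Hydrogen in place of ethyl thus gives a step beyond the scatter at this ethoxycarbonyl group as well, so the effect is not confined to the group opened in compound 2. Compound 1 stands at a limit and not a number, so the step size is only a bound: the limit of < 0.0167 h in this assay, at which 1 of the 4 values shown sits.

Going by these compounds, the actual size of the step remains open. So does whether an amide or a methyl ester at this place would give a similar step.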